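The compounds below may be only part of what the source reports. "The series", "measured", "known", "first", "only" and "open" are said of these compounds alone.

Compound 1 `COc1ccc(/C(=N\NC(=O)Nc2nnc(COc3ccc4ccccc4c3)o2)c2ccccc2)cc1` and compound 2 `C/C(=N/NC(=O)Nc1nnc(COc2ccc3ccccc3c2)o1)c1ccc([N+](=O)[O-])cc1` share one core. In a functional assay on the whole organism (strain Swiss albino) with Mus musculus as the target, in the maximal electroshock model, with a stated time of 4 h (a lower number here means that less compound is needed, a higher number that more compound is needed for the effect), compound 1 gives 300 mg/kg, and compound 2 gives 300 mg/kg, so compound 2 stands level with compound 1 in this assay, within the scatter. Compound 3 `O=C(N/N=C(/c1ccccc1)c1ccc([N+](=O)[O-])cc1)Nc1nnc(COc2ccc3ccccc3c2)o1` is not yet measured. It differs from compound 2 in one place: phenyl in place of methyl on a carbon with a double bond to nitrogen. Among the measured compounds shown here, no measured pair shows this exact change, so the size of its step is unknown; given that compound 1 carries a phenyl at that carbon and gives 300 mg/kg, the step is expected to stay within the scatter, with a value for compound 3 expected near 300 mg/kg, between 100 mg/kg and 600 mg/kg, which means an expected step of no change at the digits printed from compound 2 to compound 3 (within the scatter).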

Compound 3, minimum effective dose: 300 mg/kg
For compound 3 middle estimate and measured number coincide at the digits printed; the range from low to high includes it.
By their numbers in this assay, from the lowest: compounds 1, 2 and 3 (each within the scatter of the next).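

In this assay, phenyl in place of methyl on a carbon with a double bond to nitrogen gives no change at the digits printed from compound 2 to compound 3 (within the scatter), so swapping this single carbon for a whole aromatic ring leaves the dose unmoved. Nitro in place of methoxy on an aromatic carbon gives no change at the digits printed from compound 1 to compound 3 (within the scatter), so a second place in the molecule also shows no shift. Nothing available explains why these numbers stay level.

On these data alone, whether any group at these places can move the dose remains open. An amine in place of nitro, or a propyl chain in place of methyl, would test this.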